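A Fluorine Added to a Kinase Binder

The source may hold more compounds than are shown below. What is called first, only, known or untested is meant among the compounds shown, and "the series" means these compounds.

Three compounds have been measured so far:

Compound 1, `c1ccc(C[n+]2c[nH]c3ncncc32)cc1`, in an assay on isolated protein for inhibition of RAC-alpha serine/threonine-protein kinase (Homo sapiens), tested at 30 uM (a higher number here means more inhibition at the concentration tested (going by the name of the read-out), a lower number less inhibition), gives 9%.
Compound 2, `Fc1ccc(C[n+]2c[nH]c3ncncc32)cc1`, gives 8% in this assay.
Compound 3, `c1ccc(Cc2[nH]cnc3ncnc2-3)cc1`, gives 0% in this assay.

Compound 1 and compound 2 share a core and differ in one place: fluoro in place of hydrogen on an aromatic carbon. The step that this change made is small, a number 1 percentage points lower from compound 1 to compound 2 (within the scatter), so the two numbers cannot be told apart by this measurement. Compound 3 carries a different core; how its core differs from that of compound 1 is not broken down here, and the two values simply sit close together, both low.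

Compound 4, `Fc1ccc(Cc2[nH]cnc3ncnc2-3)cc1`, has not yet been measured. It is made from compound 3 by the same change that turned compound 1 into compound 2: fluoro in place of hydrogen on an aromatic carbon. The place of the new group is described in the same words for both pairs, so this counts as the same change, now on the core of compound 3.

The expectation rests on one thing only: when this change was made on the other core, the step from compound 1 to compound 2 was a number 1 percentage points lower from compound 1 to compound 2 (within the scatter). On that basis the step expected from compound 3 to compound 4 is a number 3 percentage points higher from compound 3 to compound 4 (within the scatter), again within the scatter. Compound 4 is therefore estimated to give 3% in this assay, somewhere between -8% and 12%, that is, essentially no inhibition at the tested concentration.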

Compound 4, a percentage reported as inhibition, at one concentration (the size of the read-out at that concentration, not a potency): 3%
Compound 4: middle estimate and measured number agree at the digits printed; the measured number falls inside the stated range.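

On the core of compound 3, putting fluoro in place of hydrogen on an aromatic carbon, para to a large group, gives a number 3 percentage points higher from compound 3 to compound 4 (within the scatter) in this assay. Set beside the step already seen on the other core, the two steps cannot be told apart, so in this small series the change reads the same on both cores: the same change on two cores in this assay, a number 1 percentage points lower (within the scatter) from compound 1 to compound 2 and a number 3 percentage points higher (within the scatter) from compound 3 to compound 4, 4 percentage points apart, within the scatter of two such steps. This agreement is only an agreement between two small steps, each lost in the scatter, among four compounds that all give low numbers at a single tested concentration; it does not show that the change would carry over in the same way on a core with clear inhibition, and it says nothing about potency.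

The compounds shown compare only hydrogen and fluoro, at one place on the six-membered aromatic ring of carbon only, so it remains open whether any group there can move the number beyond the scatter. A chloro, a methoxy, an amine or a carboxylic acid at that place, or fluoro elsewhere on the same ring, could each be tested on both cores to show whether the two cores still respond alike once a step is large enough to read.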